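A few compounds are considered here, and "the series" means these few. Any claim that something is new, unique, unknown or untested is made for them only; others in the source may bear on it.

Of the compounds shown here, three have been measured in an ADME assay for permeability, using PAMPA, at pH 7.4 (a higher number here means that the compound crosses the layer faster, a lower number that the compound crosses the layer more slowly), and no two of them differ in only one place. Compound 1 `COc1ccc(-c2nc3ccccc3o2)cc1NC(=O)c1cc([N+](=O)[O-])ccc1Cl` gives 274 10^-6 cm/s, the highest of the three numbers. Compound 3 `COc1cc(Cl)c(C(=O)Nc2cccc(-c3nc4ccccc4s3)c2)cc1[N+](=O)[O-]` gives 12 10^-6 cm/s, and compound 2 `O=C(Nc1nc(-c2ccc(Cl)cc2)cs1)c1cc([N+](=O)[O-])ccc1Cl` gives 3 10^-6 cm/s. Both of these numbers lie lower than that of compound 1, and both gaps are beyond the scatter.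

Compound 4 `O=C(Nc1cc(-c2nc3ccccc3o2)ccc1F)c1cc([N+](=O)[O-])ccc1Cl` departs from compound 1 at a single place: fluoro in place of methoxy on an aromatic carbon. The place of this exchange is ortho to a large group and para to a 1,3-benzoxazol-2-yl group.

Going by the values given here, no measured pair shows what this exchange does in this assay, so the expectation has little to rest on. A downward step of modest size, close to the edge of the scatter, is expected because compound 1 at 274 10^-6 cm/s stands at the top of the three numbers, and the other two compounds lie far lower. A step to a number above that of compound 1 is not ruled out. The expected change is a 2.3-fold lower number from compound 1 to compound 4 (0.36 log units; beyond the scatter). For compound 4 the estimated value is 120 10^-6 cm/s, with an expected range from 30 10^-6 cm/s to 400 10^-6 cm/s.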

Compound 4, apparent permeability: 214 10^-6 cm/s
Estimate against measurement, compound 4: 1.8-fold (0.25 log units) below; low and high end bracket the measured number.
By their numbers in this assay, from the lowest: compound 2; then compound 3; then compounds 4 and 1 (each within the scatter of the next).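

In this assay, going by these compounds alone, the exchange of methoxy for fluoro on the aromatic carbon ortho to a large group and para to a 1,3-benzoxazol-2-yl group gives a 1.3-fold lower number from compound 1 to compound 4 (0.11 log units; within the scatter) and so provides the first pair in the set that differs in one place. Methoxy, with 2 heavy atoms and 1 hydrogen-bond acceptor, and fluoro, with 1 heavy atom and 0 hydrogen-bond acceptors, thus give numbers that cannot be told apart at this position on the core of compound 1. Nothing measured here accounts for how close the two numbers lie.

This single pair leaves open whether an amine, a carboxylic acid or a longer alkoxy chain such as butoxy at the same position would also give a number within the scatter of that of compound 1. It also leaves open whether fluoro in place of methoxy would give a similar step on another core, and which of the several differences separating compound 1 from compound 2 and compound 3 matter in this read-out.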